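The source may hold more compounds than are shown below. What is called first, only, known or untested is meant among the compounds shown, and "the series" means these compounds.

Measured compounds in a functional assay on SK-BR-3 cells (Homo sapiens) for cytotoxicity, read by MTT assay, with a stated time of 72 h; on this read-out lower numbers stand for an effect already at smaller amounts and higher numbers for an effect only at larger amounts of compound:
compound 1, `COc1ccc(Nc2cc(C(C)C)oc(=O)c2)cc1`: compound 1 reaches only the limit of > 30 uM in this assay, not a number.
compound 2, `COc1ccc(Nc2cc(C3CCCCC3)oc(=O)c2)cc1`: compound 2 gives 5.29 uM.
compound 3, `COc1ccc(Nc2cc(-c3ccccc3)oc(=O)c2)cc1`: compound 3 gives 0.079 uM.

Compound 3 holds the lowest number among the values shown; the nearest measured value belongs to compound 2, separated by a 67-fold lower number from compound 2 to compound 3 (1.83 log units; beyond the scatter). The value of compound 1 stands as a limit only (the limit of > 30 uM in this assay, at which 1 of the 3 values shown sits).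

Compound 4, `COc1ccc(Nc2cc(C)oc(=O)c2)cc1`, is not yet measured. It differs from compound 3 by methyl in place of phenyl on an aromatic carbon. Among the compounds with values here, two measured steps bear on this change, both in the opposite direction: an at least 370-fold lower number from compound 1 to compound 3 (2.57 log units; beyond the scatter) and a 67-fold lower number from compound 2 to compound 3 (1.83 log units; beyond the scatter). In each, phenyl in place of an alkyl group gave a large lower number, so methyl in place of phenyl is expected to give a large higher number. Compound 1, with isopropyl at this position, reached only the limit of this assay, and the same may well happen for compound 4.

Compound 4 is therefore expected to show a 380-fold higher number from compound 3 to compound 4 (2.58 log units; beyond the scatter). For compound 4 the estimate is 30 uM, with a range of 8 uM to 100 uM, and a limit rather than a number is quite possible.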

Compound 4, concentration for half-maximal effect: > 30 uM
Compound 4: only a limit was reported; the forecaster's own chance of this, stated with the estimate: 60%; the middle value sits exactly at the limit.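

Methyl in place of phenyl gives an at least 370-fold higher number from compound 3 to compound 4 (2.57 log units; beyond the scatter), and methyl in place of cyclohexyl gives an at least 5.6-fold higher number from compound 2 to compound 4 (0.75 log units; beyond the scatter). In this assay compound 4 therefore joins compound 1 with a limit rather than a number, leaving phenyl and cyclohexyl as the only groups shown at this position to give a number: the limit of > 30 uM in this assay, at which 2 of the 4 values shown sit. Compound 1 and compound 4 both stand as limits, so the step between them cannot be read and methyl and isopropyl cannot be ranked.

On these data alone, whether the aromatic ring of phenyl carries the low number of compound 3 remains open, as cyclohexyl in compound 2 also gives a number, though a much higher one. As far as these compounds go, how a pyridyl ring, a benzyl group or a longer chain such as n-hexyl would read at this position also remains open.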